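The source may report more compounds than this note shows. Statements on the series, on what has been measured and on what is new or still open speak of the compounds shown alone.

Working notes on the series.

Compound 1 `CCc1nc2c(-c3ccc(Cl)cc3Cl)ccnc2n1C(CCOC)C1CCC1` is the reference point here. In an assay for binding affinity to Corticotropin releasing factor receptor (Rattus norvegicus) (on this read-out lower numbers stand for stronger inhibition and higher numbers for weaker inhibition), compound 1 gives 2.4 nM, the lowest of the three numbers recorded so far. Compound 2 `CCCC(C)n1c(CC)nc2c(-c3ccc(C(C)OC)cc3Cl)ccnc21` gives 3.5 nM, a result that sits with compound 1 inside the usual scatter, so the two cannot be told apart on this read-out. Compound 3 `CCCC(C)n1c(CC)nc2c(-c3ccc(Cl)cc3C(C)=O)ccnc21` gives 95.6 nM, a number well beyond the scatter from compound 1 and the weakest binding recorded in the set. Compounds 2 and 3 carry a different substituent on the chain nitrogen and a different aryl group from compound 1, so neither defines a single-point step to it.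

The next compound, compound 4 `CCc1nc2c(-c3ccc(Cl)cc3Cl)ccnc2n1C(C)C1CCC1`, differs from compound 1 in one place: hydrogen in place of methoxymethyl on a saturated chain carbon, two bonds along the chain from an aromatic nitrogen and a saturated ring carbon. The change shortens the chain on the core nitrogen while leaving the cyclobutyl and the dichlorophenyl untouched.

Among the measured compounds shown here, no single-point step between measured compounds is available to calibrate this change. The expectation is a modest loss of affinity, possibly no larger than the scatter, and the estimated step of a 2.5-fold higher number from compound 1 to compound 4 (0.40 log units; beyond the scatter) is a small weakening. Compound 4 is therefore estimated at 6 nM, with a range of 1.5 nM to 25 nM.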

Compound 4, inhibition constant: 1 nM
Compound 4: middle estimate off by 6.0-fold (0.78 log units), on the high side, outside the stated range (below it).
By their numbers in this assay, from the lowest: compound 4; then compounds 1 and 2 (each within the scatter of the next); then compound 3.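

In this assay, among the compounds shown here, going from 1-cyclobutyl-3-methoxypropyl to 1-cyclobutylethyl gives a 2.4-fold lower number from compound 1 to compound 4 (0.38 log units; beyond the scatter), the first single-point step, and it runs toward stronger binding. At this saturated chain carbon, then, the methoxymethyl with its 3 heavy atoms and 1 hydrogen-bond acceptor is not required for binding, at least with the cyclobutyl and the dichlorophenyl held constant, and hydrogen is enough to keep the number low. Nothing available here accounts for the direction or size of this step.

Since the change removes the ether oxygen and shortens the chain together, the compounds shown cannot separate those two features; a plain propyl chain in place of the 2-methoxyethyl, or an amine at its end, would bear on that question. On these data alone, it also remains open whether the same change would move the number in the same direction with the different chain and aryl groups of compound 2 and compound 3, and whether anything larger than methyl at this position would be tolerated once the ether oxygen is gone.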